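The source may hold more compounds than are shown below. What is called first, only, known or untested is meant among the compounds shown, and "the series" means these compounds.

Compound 1 `CSc1ccc(C(=O)/C(=C/c2cc3ccccc3s2)c2ccc(Cl)c(Cl)c2)cc1`: 87.1%
Compound 2 `CSc1ccc(C(=O)/C(=C/c2cccnc2)c2ccc(Cl)c(Cl)c2)cc1`: 88.6%

In an ADME assay on Vero cells (Chlorocebus sabaeus) for cytotoxicity, read by MTT assay, tested at 100 uM (a higher number here means a weaker effect of the compound at the concentration tested, a lower number a stronger effect), compound 2 stands highest of the two values, with compound 1 nearest; the step of a number 1.5 percentage points higher from compound 1 to compound 2 (within the scatter) lies within the scatter. Compound 3 `CSc1ccc(C(=O)/C(=C/c2ccccn2)c2ccc(Cl)c(Cl)c2)cc1` differs from compound 2 in one place: pyridin-2-yl in place of pyridin-3-yl on a double-bonded chain carbon bound to a double-bonded chain carbon. Among the compounds with values here, the only measured step, from compound 1 to compound 2, swapped a far larger ring system for a pyridine ring and still moved the number only within the scatter, so moving the ring nitrogen from one position to another is expected to change this assay by nothing beyond the scatter, with a number 0.6 percentage points lower from compound 2 to compound 3 (within the scatter) as the expected step. Compound 3 is therefore estimated at 88%, with a range from 78% to 96%.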

Compound 3, a percentage reported as activity, at one concentration (the size of the read-out at that concentration, not a potency): 89.6%
Beside the measured number, compound 3's estimate is 1.6 percentage points below it, within the range that was stated.
By their numbers in this assay, from the lowest: compounds 1, 2 and 3 (each within the scatter of the next).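

In this assay pyridin-2-yl in place of pyridin-3-yl gives a number 1 percentage points higher from compound 2 to compound 3 (within the scatter) and so the place of the ring nitrogen does not separate these two compounds. Pyridin-2-yl in place of 1-benzothiophen-2-yl gives a number 2.5 percentage points higher from compound 1 to compound 3 (within the scatter) and so this pyridine ring, like pyridin-3-yl, cannot be told apart from the larger ring system. Nothing available offers a cause for these small steps.

All three groups at this position are aromatic rings. From the compounds shown here alone, whether an amine or a carboxylic acid on the same carbon would read alike remains open.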